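The source may report more compounds than this note shows. Statements on the series, on what has been measured and on what is new or still open speak of the compounds shown alone.

Compound 1 `Cc1cc(C(=O)N[C@H]2CC[C@@H](NC(=O)c3cc(F)cnc3Oc3cccc(-c4cccc(CN5C[C@@H](C)N[C@@H](C)C5)c4O)c3)CC2)nn1C` is the starting point here. For the measured compounds named here, in a physicochemical assay for solubility, at pH 7.4 (on this read-out higher numbers stand for higher solubility and lower numbers for lower solubility), compound 1 gives 470000 nM, the lower of the two numbers measured so far. The other measured molecule, compound 2 `Cc1cc(C(=O)N[C@H]2CC[C@@H](NC(=O)c3cc(F)cnc3Oc3cccc(-c4ccc(CN5C[C@@H](C)N[C@@H](C)C5)cc4)c3)CC2)nn1C`, gives 1300000 nM, and that gap lies beyond the usual scatter of repeated measurements.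

The next molecule, compound 3 `Cc1cc(C(=O)N[C@H]2CC[C@@H](NC(=O)c3cc(F)cnc3Oc3cccc(-c4cccc(CN5C[C@@H](C)N[C@@H](C)C5)c4)c3)CC2)nn1C`, keeps the core of compound 1 and makes one change: hydrogen in place of hydroxy on an aromatic carbon. That carbon belongs to a six-membered aromatic ring of carbon only, ortho to a (3,5-dimethylpiperazin-1-yl)methyl group.

Going by the values given here, no pair of measured compounds shows this single change on its own, so the size of the step cannot be read directly from the data. The two measured numbers offer only a rough span. In this assay, a small upward step is expected, probably staying within the scatter, and the estimated step is a 1.7-fold higher number from compound 1 to compound 3 (0.23 log units; within the scatter). For compound 3 the expected value is 800000 nM, with an estimated range from 350000 nM to 1800000 nM.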

Compound 3, solubility: > 1500000 nM
Compound 3 gave a limit, no number (the forecaster's own chance of this, stated with the estimate: 5%); middle value at least 1.8-fold (0.27 log units) from the limit.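

In this assay, compound 3 gives > 1500000 nM, which is a limit of the assay and not a number. Even so, replacing the hydroxy with hydrogen on this aromatic carbon, ortho to a (3,5-dimethylpiperazin-1-yl)methyl group, gives a clear result: an at least 3.1-fold higher number from compound 1 to compound 3 (0.50 log units; beyond the scatter). Compound 1 and compound 2 differ in more than one place, so only this new pair isolates the change and shows that this single position can move the read-out past ordinary scatter, although the printed step marks only the smallest size it could have and its upper end stays unknown: the limit of > 1500000 nM in this assay, at which 1 of the 3 values shown sits.

As far as these compounds go, what a methoxy group, a fluorine atom or an amine on this same aromatic carbon would give in this assay remains open, so this one pair cannot show whether the outcome is specific to the hydroxy or would follow other replacements at this position. From the compounds shown here alone, it also remains open whether the same exchange of hydroxy for hydrogen would produce a similar step on a different core or at another carbon of this ring.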